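Permeability Outlook for a Chlorophenoxy Analog, Compound 4

The compounds below may be only part of what the source reports. "The series", "measured", "known", "first", "only" and "open" are said of these compounds alone.

Of the compounds shown here, three sharing one core have been measured in an ADME assay for permeability, using PAMPA, with a stated time of 30 min, at pH 7.4; on this read-out lower numbers stand for lower permeability and higher numbers for higher permeability. Compound 1 `COc1ccccc1Oc1ccc2c(NCCCNCc3ccco3)ccnc2c1` gives 317 10^-6 cm/s, compound 2 `Fc1ccc(Cc2ccc3c(NCCCNCc4ccco4)ccnc3c2)c(Cl)c1` gives 23 10^-6 cm/s, and compound 3 `FC(F)(F)c1ccc(-c2ccc3c(NCCCNCc4ccco4)ccnc3c2)cc1` gives 237 10^-6 cm/s. Compound 3 stands second highest of the three: the step of a 1.3-fold lower number from compound 1 to compound 3 (0.13 log units; within the scatter) is within the scatter, while the steps of a 14-fold lower number from compound 1 to compound 2 (1.14 log units; beyond the scatter) and a 10-fold higher number from compound 2 to compound 3 (1.01 log units; beyond the scatter) are both large. Compound 4 `Clc1ccc(Oc2ccc3c(NCCCNCc4ccco4)ccnc3c2)cc1` carries the change (4-chlorophenoxy in place of 4-(trifluoromethyl)phenyl on an aromatic carbon). The step that bears most on this is the one where 4-(trifluoromethyl)phenyl replaced 2-methoxyphenoxy, giving a 1.3-fold lower number from compound 1 to compound 3 (0.13 log units; within the scatter), a difference within the scatter. The two large steps both involve the 2-chloro-4-fluorobenzyl compound 2, a different kind of change, and do not apply here. Since compound 4 carries a phenoxy group as compound 1 does, a step of only a 1.1-fold higher number from compound 3 to compound 4 (0.06 log units; within the scatter) in this assay is expected, within the scatter. Compound 4 is therefore estimated at 270 10^-6 cm/s, with a range from 150 10^-6 cm/s to 420 10^-6 cm/s.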

Compound 4, apparent permeability: 317 10^-6 cm/s
Estimate against measurement, compound 4: 1.2-fold (0.07 log units) below, within the range that was stated.
By their numbers in this assay, from the lowest: compound 2; then compounds 3, 1 and 4 (each within the scatter of the next).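

On this aromatic carbon of the shared core, in this assay, 4-chlorophenoxy in place of 4-(trifluoromethyl)phenyl gives a 1.3-fold higher number from compound 3 to compound 4 (0.13 log units; within the scatter), so a ring attached through an oxygen and one attached directly are not told apart here. Changing only the ring on that oxygen, 4-chlorophenyl in place of 2-methoxyphenyl, gives no change at the digits printed from compound 1 to compound 4 (within the scatter), which shows that a second phenoxy group with a different substituent also stays within the scatter of compound 1. The step of a 14-fold higher number from compound 2 to compound 4 (1.14 log units; beyond the scatter) leaves compound 2 as the lowest of the four and the only one apart from the others, and no measurement shown explains this.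

On these data alone, whether a plain benzyl group would also stand apart remains open. So does whether an amine or a carboxylic acid on this carbon would stay with compounds 1, 3 and 4.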